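This account rests on a few compounds, and the source may have more. Where it says the series, first, only, none or still open, it means among the compounds named here.

Of the compounds shown here, three have been measured in a functional assay on A-431 cells (Homo sapiens) for antiproliferative activity, read by MTT assay, with a stated time of 72 h; on this read-out lower numbers stand for stronger inhibition and higher numbers for weaker inhibition. Compound 1 `COc1cc2ncnc(Nc3ccc(Br)cc3)c2cc1OCCCCC(=O)Nc1ccc(S(N)(=O)=O)cc1` gives 6570 nM in this assay, and compound 2 `COc1cc2ncnc(Nc3ccc(OCc4cccc(F)c4)c(Cl)c3)c2cc1OCCCCC(=O)Nc1ccc(S(N)(=O)=O)cc1` gives 7790 nM. Compound 3 `NS(=O)(=O)c1ccc(NC(=S)Nc2ccc3ncnc(Nc4cccc(Br)c4)c3c2)cc1` gives 20700 nM, the highest number of the three: its gap to compound 2 and its gap to compound 1 are both beyond the scatter, so it inhibits proliferation the least of the three.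

Compound 4 `CCc1ccc(Nc2ncnc3ccc(NC(=S)Nc4ccc(S(N)(=O)=O)cc4)cc23)cc1` has not yet been measured. It differs from compound 3 in one place: 4-ethylphenyl in place of 3-bromophenyl on a nitrogen on an aromatic ring. Going by the values given here, no measured pair shows this change, so its effect is unknown. The expectation is a step from compound 3 to compound 4 of a 1.3-fold higher number from compound 3 to compound 4 (0.10 log units; within the scatter), within the scatter or somewhat weaker. Compound 4 is therefore expected to give about 26000 nM in this assay, between 8000 nM and 80000 nM.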

Compound 4, half-maximal inhibitory concentration: 38400 nM
Beside the measured number, compound 4's estimate is 1.5-fold (0.17 log units) below it; the measured number falls inside the stated range.
By their numbers in this assay, from the lowest: compounds 1 and 2 (each within the scatter of the next); then compounds 3 and 4 (each within the scatter of the next).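

In this assay, placing 4-ethylphenyl instead of 3-bromophenyl on this nitrogen gives a 1.9-fold higher number from compound 3 to compound 4 (0.27 log units; within the scatter), so the two groups cannot be told apart at this position. Going by these compounds alone, this pair offers the only direct reading of a change at this place on the thiourea-linked compounds. Nothing available accounts for the result.

The step exchanges both the substituent and its printed ring position, leaving their separate contributions unresolved. Going by these compounds, whether 3-ethylphenyl, or a phenyl ring carrying an amine or a carboxylic acid, would read differently also remains open.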